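Lengthening an Ester Chain: Expected Effect on Cell Migration

The source may hold more compounds than are shown below. What is called first, only, known or untested is meant among the compounds shown, and "the series" means these compounds.

Of the compounds shown here, two have been measured in a functional assay on HT-1080 cells (Homo sapiens), read by transwell migration, with a stated time of 24 h, tested at 0.1 uM; a higher number here means a weaker effect of the compound at the concentration tested, a lower number a stronger effect. Compound 1 `CC(=O)OCc1ccc2oc(=O)c(C(=O)Sc3cccc(Br)c3)cc2c1` gives 79.6%, and compound 2 `CCCC(=O)OCc1ccc2oc(=O)c(C(=O)Oc3cccc(Br)c3)cc2c1` gives 88.6%; these two numbers sit within the usual scatter of each other, so neither compound can be called the stronger. Compound 3 `CCCCCCC(=O)OCc1ccc2oc(=O)c(C(=O)Oc3cccc(Br)c3)cc2c1` differs from compound 2 in one place: propyl in place of hydrogen on a saturated chain carbon, three bonds along the chain from a carbonyl carbon. Among the compounds with values here, no measured pair shows what this kind of change does in this assay, so only a small step, if any beyond the scatter, is expected, and the expected step is a number 2.6 percentage points lower from compound 2 to compound 3 (within the scatter). Compound 3 is therefore estimated at 86%, with a range from 70% to 100%.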

Compound 3, a percentage reported as activity, at one concentration (the size of the read-out at that concentration, not a potency): 89.4%
Estimate against measurement, compound 3: 3.4 percentage points below, within the range that was stated.
By their numbers in this assay, from the lowest: compounds 1, 2 and 3 (each within the scatter of the next).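

Within the data shown here, putting propyl in place of hydrogen on a saturated chain carbon, three bonds along the chain from a carbonyl carbon, gives the first step in this assay between compounds that differ in one place: a number 0.8 percentage points higher from compound 2 to compound 3 (within the scatter). At this place, then, the longer chain produces no step beyond the scatter at the single concentration tested. No measurement of any other property accompanies this result.

From the compounds shown here alone, it remains open whether a much longer chain, or a chain carrying an amine or a carboxylic acid, would produce a step beyond the scatter here.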